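The source may hold more compounds than are shown below. What is called first, only, known or untested is meant among the compounds shown, and "the series" means these compounds.

Among the compounds with values here, compound 3 `COc1ccc(C(=O)/C(=C/c2ccc(Cl)cc2Cl)CCOC(C)=O)cc1` gives the only outright number in a functional assay on A549 cells (Homo sapiens) for inhibition, read by XTT assay, with a stated time of 48 h (on this read-out lower numbers stand for stronger inhibition and higher numbers for weaker inhibition), at 69200 nM. Compound 1 `CCC(/C=C(\COC(C)=O)C(=O)c1ccc(OC)cc1)CC` reaches only the limit of this assay, > 100000 nM. Compound 2 `COc1ccc(C(=O)/C(=C/c2ccccc2F)CCOC(C)=O)cc1` likewise stops at the limit, > 100000 nM. Within the data shown here, the single measured step, an at least 1.4-fold lower number from compound 2 to compound 3 (0.15 log units; that floor lies within the scatter), rests on that limit of > 100000 nM in this assay, at which 2 of the 3 values shown sit, and says little about size. Compound 4 `CCC(/C=C(\CCOC(C)=O)C(=O)c1ccc(OC)cc1)CC` differs from compound 3 by pentan-3-yl in place of 2,4-dichlorophenyl on a double-bonded chain carbon bound to a double-bonded chain carbon. Among the measured compounds shown here, no measured step bears on this change. For the measured compounds named here, compound 1 carries the same pentan-3-yl group and sits at the limit, whereas compound 3 with its aromatic ring is the sole compound with a measurable value. It is therefore expected that compound 4 slips back toward the limit, a step of a 2.2-fold higher number from compound 3 to compound 4 (0.34 log units; beyond the scatter). Compound 4 is estimated at 150000 nM, within 50000 nM to 500000 nM.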

Compound 4, half-maximal inhibitory concentration: > 100000 nM
Compound 4 ended at the assay's limit (the forecaster's own chance of this, stated with the estimate: 70%); the middle value lies beyond the limit too.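

In this assay, within the data shown here, pentan-3-yl in place of 2,4-dichlorophenyl on this double-bonded chain carbon gives an at least 1.4-fold higher number from compound 3 to compound 4 (0.15 log units; that floor lies within the scatter), so this change does not keep the one outright number in the set, though the size of the step stays unknown. Compound 4 joins the other compounds without a number: the limit of > 100000 nM in this assay, at which 3 of the 4 values shown sit. The steps to compound 4 from compound 1 and compound 2 join two limits and cannot be read. The compounds shown leave open whether an amine or a carboxylic acid in this place would give an outright number.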